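Compound 3 to compound 4: adding chloro to the phenyl

A few compounds are considered here, and "the series" means these few. Any claim that something is new, unique, unknown or untested is made for them only; others in the source may bear on it.

In a functional assay on NCI-H460 cells (Homo sapiens) for inhibition, read by MTT assay, with a stated time of 24 h, tested at 100 ug/mL (on this read-out higher numbers stand for more inhibition of growth at the one concentration tested and lower numbers for less inhibition of growth), compound 1 (`O=C(CCCCC1CCSS1)Nc1ccccn1`) gives 39.3% and compound 2 (`O=C(CCCCC(S)CCS)Nc1ccc(Br)cn1`) gives 55.9% as measured values. Compound 3 (`O=C(CCCCC(CCSC(=O)c1ccccc1)SC(=O)c1ccccc1)Nc1ccccc1`) is reported as "not active" (no number reported) with no number, so it has no numeric place beside them. Compound 4 (`O=C(CCCCC(CCSC(=O)c1ccccc1)SC(=O)c1ccccc1)Nc1ccc(Cl)cc1`) differs from it in one place (chloro in place of hydrogen on an aromatic carbon) with phenyl going to 4-chlorophenyl, chloro in place of hydrogen on an aromatic carbon. Within the data shown here, no measured pair shows what this change does. In this assay a small upward step is expected, not clearly beyond the usual scatter, with compound 3 at "not active" (no number reported) as the starting point. Compound 4 is estimated at 15% with an expected range from 0% to 35% in this read-out.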

Compound 4, percent growth inhibition at one concentration: "not active" (no number reported)
Compound 4: no number reported; the estimate stays without a comparison.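

In this assay compound 3 gives "not active" (no number reported) and compound 4 gives "not active" (no number reported) so no step can be read between them. Going by these compounds, whether phenyl to 4-chlorophenyl changes growth inhibition stays open. No evidence bears on this result.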